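Swapping an Ester for a Pyrrolidine Ring

This account rests on a few compounds, and the source may have more. Where it says the series, first, only, none or still open, it means among the compounds named here.

Of the compounds shown here, two sharing one core have been tested in a toxicity assay on NIH3T3 cells (Mus musculus) for cytotoxicity, read by resazurin assay; a higher number here means that more compound is needed for the effect, a lower number that less compound is needed. Compound 1, `COC(=O)c1ccc(NCc2cncn2Cc2ccc(N)cc2)cc1-c1ccccc1`, gives in this assay only a limit of the assay, > 10000 nM. Compound 2, `COC(=O)c1ccc(NCc2cncn2Cc2ccc(-c3ccccc3)cc2)cc1-c1ccccc1`, likewise gives only a limit in this assay, > 1000 nM. Among the measured compounds shown here, the single change between them, phenyl in place of amino on an aromatic carbon, gives a step that the two limits leave unreadable from compound 1 to compound 2; its size cannot be read, as the limit of > 1000 nM in this assay, at which 1 of the 2 values shown sits, and the limit of > 10000 nM in this assay, at which 1 of the 2 values shown sits, show. For the measured compounds named here, compound 2 thus stands at a limit in this assay, and the one further value shown is a limit as well.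

Compound 3, `c1ccc(-c2ccc(Cn3cncc3CNc3ccc(N4CCCC4)c(-c4ccccc4)c3)cc2)cc1`, differs from compound 2 in one place: pyrrolidin-1-yl in place of methoxycarbonyl on an aromatic carbon. Going by the values given here, no measured step concerns an exchange of this kind, and the only step available is unreadable, so nothing sets an expected direction or size beyond the usual scatter. Compound 3 is therefore expected at about 5000 nM, within a range from 1000 nM to 30000 nM. The step that this estimate implies is a step that the limit leaves unreadable from compound 2 to compound 3.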

Compound 3, half-maximal effective concentration: > 1000 nM
Compound 3 ended at the assay's limit; the forecaster's own chance of this, stated with the estimate: 60%; the middle value lies beyond the limit too.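

Compound 3 gives only a limit of the assay, and so does compound 2, so no step between compound 2 and compound 3 can be read: the limit of > 1000 nM in this assay, at which 2 of the 3 values shown sit.

The compounds shown leave open how much of either compound is needed for the effect in this assay, and whether exchanging methoxycarbonyl for pyrrolidin-1-yl changes that amount at all.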